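Halogen change on the hydroxyphenyl arm of the shared core

The source may report more compounds than this note shows. Statements on the series, on what has been measured and on what is new or still open speak of the compounds shown alone.

Of the compounds shown here, two have been measured so far in a functional assay on HCT-116 cells (Homo sapiens) for antiproliferative activity; a higher number here means a weaker inhibitor, a lower number a stronger inhibitor. Compound 1 `CC[C@H](C)[C@H]1C(=O)N[C@H](Cc2ccc(O)c(Br)c2)C(=O)N[C@@H](C(C)(C)O)C(=O)O[C@H](c2ccccc2)[C@H](C)/C=C/C=C(\C)[C@H](OC)C/C=C(\C)C(=O)N1C` gives 3.88 nM in this assay. Compound 2 `CC[C@H](C)[C@H]1C(=O)N[C@H](Cc2cc(Cl)c(O)c(Cl)c2)C(=O)N[C@@H](C(C)(C)O)C(=O)O[C@H](c2ccccc2)[C@H](C)/C=C/C=C(\C)[C@H](OC)C[C@@H]2O[C@@]2(C)C(=O)N1C` differs from compound 1 in more than one place; in this assay compound 2 gives 2.11 nM. Among the two numbers, compound 1 holds the higher one, but the gap to compound 2 is within the scatter, so the two values cannot be ranked.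

Compound 3 `CC[C@H](C)[C@H]1C(=O)N[C@H](Cc2cc(Cl)c(O)c(Cl)c2)C(=O)N[C@@H](C(C)(C)O)C(=O)O[C@H](c2ccccc2)[C@H](C)/C=C/C=C(\C)[C@H](OC)C/C=C(\C)C(=O)N1C` is not yet measured. It keeps the core of compound 1 and carries the change (3,5-dichloro-4-hydroxyphenyl in place of 3-bromo-4-hydroxyphenyl on a saturated chain carbon bound to a saturated ring carbon). Among the compounds with values here, no pair of measured compounds isolates this single change; compound 2 carries the same 3,5-dichloro-4-hydroxyphenyl group, but its other difference from compound 1 means its value shows only that a compound with that group can sit near compound 1 in this assay.

On this basis, the step of a 1.3-fold lower number from compound 1 to compound 3 (0.11 log units; within the scatter) is expected to stay within the scatter, with no clear direction. Compound 3 is therefore estimated at 3 nM in this assay, with a range from 1.2 nM to 7.5 nM.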

Compound 3, half-maximal inhibitory concentration: 1.6 nM
Compound 3: the middle estimate sits 1.9-fold (0.27 log units) above what was measured; low and high end bracket the measured number.
By their numbers in this assay, from the lowest: compounds 3, 2 and 1 (each within the scatter of the next, the first and the last beyond it).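

In this assay, placing 3,5-dichloro-4-hydroxyphenyl in place of 3-bromo-4-hydroxyphenyl on a saturated chain carbon bound to a saturated ring carbon gives a 2.4-fold lower number from compound 1 to compound 3 (0.38 log units; beyond the scatter), a modest step but the first in this series that isolates a single change at this position. Compounds 1 and 2 differ in more than one place and could not be ranked, whereas this pair shows that the aryl substitution alone can move the antiproliferative read-out by more than the scatter, with the rest of the core of compound 1 held constant. Nothing available explains the direction of this step or connects it to any measured property of the two groups.

The step removes one bromine and adds two chlorines at once, so the halogen's identity and the number of halogens remain inseparable here. A monochloro or dibromo counterpart on the same core would separate those two factors, while an unsubstituted 4-hydroxyphenyl group or a methoxy group in place of the hydroxyl would test how much the halogens and the hydroxyl each contribute.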